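Benzoyl halogen series: removing the fluoro

This account rests on a few compounds, and the source may have more. Where it says the series, first, only, none or still open, it means among the compounds named here.

Compound 1 `COc1cc(-c2nnc3n2NC(c2ccco2)C(C(=O)c2ccc(Br)cc2)S3)cc(OC)c1OC` and compound 2 `COc1cc(-c2nnc3n2NC(c2ccco2)C(C(=O)c2ccc(F)cc2)S3)cc(OC)c1OC` share one core and differ only in the halogen on the benzoyl ring. In a functional assay on A549 cells (Homo sapiens) for cytotoxicity, read by MTT assay, with a stated time of 48 h (a higher number here means a weaker inhibitor, a lower number a stronger inhibitor), compound 1 gives 42100 nM and compound 2 gives 53700 nM. The step of a 1.3-fold higher number from compound 1 to compound 2 (0.11 log units; within the scatter) stays within the scatter, so the two values cannot be ordered. Among the measured compounds shown here, compound 2 holds the higher of the two numbers, with compound 1 as its only neighbour.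

Compound 3 `COc1cc(-c2nnc3n2NC(c2ccco2)C(C(=O)c2ccccc2)S3)cc(OC)c1OC` carries the change (hydrogen in place of fluoro on an aromatic carbon); cut one bond further out this reads 4-fluorophenyl to phenyl, or (4-fluorophenyl)carbonyl to benzoyl. For the measured compounds named here, the only measured step at this position, bromo to fluoro, moved nothing beyond the scatter, and no pair covers the loss of the halogen itself. The expected step of a 1.1-fold lower number from compound 2 to compound 3 (0.03 log units; within the scatter) is therefore none beyond the scatter. For compound 3 the estimate in this assay is 50000 nM, with a range from 20000 nM to 125000 nM.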

Compound 3, half-maximal inhibitory concentration: 33400 nM
Compound 3: the middle estimate sits 1.5-fold (0.18 log units) above what was measured; the range from low to high includes it.
By their numbers in this assay, from the lowest: compounds 3, 1 and 2 (each within the scatter of the next).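

In this assay the loss of the halogen itself is now covered: hydrogen in place of fluoro is a 1.6-fold lower number from compound 2 to compound 3 (0.21 log units; within the scatter) and hydrogen in place of bromo is a 1.3-fold lower number from compound 1 to compound 3 (0.10 log units; within the scatter) and neither step leaves the scatter. Bromo, fluoro and hydrogen on this aromatic carbon therefore cannot be ordered among compound 1, compound 2 and compound 3, so for these three the presence of a halogen at this place makes no readable difference. No measurement is at hand that would explain this result.

Still open, from the compounds shown here alone, is whether another group at this place, such as a methoxy, a nitrile or an amine, would move the number beyond the scatter. Also open, going by these compounds, is whether a change elsewhere on the shared core would do so.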